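Chloro for Fluoro: Expected Cytotoxicity of Compound 4

The source may report more compounds than this note shows. Statements on the series, on what has been measured and on what is new or still open speak of the compounds shown alone.

Of the compounds shown here, three sharing one core have been tested in an ADME assay on HepG2 cells (Homo sapiens) for cytotoxicity, read by neutral red uptake, with a stated time of 24 h; on this read-out higher numbers stand for lower toxicity in this test and lower numbers for higher toxicity in this test. Compound 1 `Clc1ccc(C(Nc2ccnc3cc(Cl)ccc23)c2ccc(Cn3ccnc3)cc2)cc1` gives 22 uM, compound 2 `Fc1cc(C(Nc2ccnc3cc(Cl)ccc23)c2ccc(Cl)cc2)ccc1CN1CCCC1` gives 12 uM, and compound 3 `Clc1ccc(C(Nc2ccnc3cc(Cl)ccc23)c2ccc(CN3CCNCC3)cc2)cc1` gives 1.8 uM. Compound 2 stands second highest of the three numbers: compound 1 lies within the usual scatter of it, while compound 3 lies beyond it. Compound 4 `Clc1ccc(C(Nc2ccnc3cc(Cl)ccc23)c2ccc(CN3CCCC3)c(Cl)c2)cc1` differs from compound 2 by chloro in place of fluoro on an aromatic carbon. Among the compounds with values here, the only measured step, a 12-fold lower number from compound 1 to compound 3 (1.09 log units; beyond the scatter), concerns a different part of the molecule, the group on the saturated chain carbon, and tells nothing about a halogen swap on an aromatic ring. Within the data shown here, no step bears on the change, so the expected step is none beyond the scatter. For compound 4 in this assay the expected value is 12 uM, with a range from 5 uM to 30 uM. That expectation corresponds to a step of no change at the digits printed from compound 2 to compound 4 (within the scatter).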

Compound 4, half-maximal toxic concentration: 4 uM
The estimate for compound 4 lay 3.0-fold (0.48 log units) above the measured number; measured number below the stated range.
By their numbers in this assay, from the lowest: compound 3; then compound 4; then compounds 2 and 1 (each within the scatter of the next).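

In this assay, this position responds to the choice of halogen: chloro in place of fluoro, on the aromatic carbon ortho to the (pyrrolidin-1-yl)methyl group, gives a 3.0-fold lower number from compound 2 to compound 4 (0.48 log units; beyond the scatter). The swap exchanges one heavy atom for another and adds no ring, hydrogen-bond donor, hydrogen-bond acceptor or net charge, yet the number moves toward higher toxicity in this test. No measurement at hand explains this shift. Going by these compounds, whether a methoxy group or a nitrile at this position would lower the number further remains open. Also open, on these data alone, is whether the same halogen swap would give a similar step with piperazin-1-yl on the chain.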